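This account rests on a few compounds, and the source may have more. Where it says the series, first, only, none or still open, it means among the compounds named here.

Compounds measured so far:
Compound 1, `COc1cc(OC)c(C(=O)/C=C/c2cc(OC)c(OC)cc2OC)c(OC)c1`, with 108000 nM in a functional assay on HeLa cells (Homo sapiens) for inhibition, read by MTT assay, with a stated time of 72 h; on this read-out higher numbers stand for weaker inhibition and lower numbers for stronger inhibition.
Compound 2, `COc1cc(OC)c(OC)cc1/C=C/C(=O)c1ccc([N+](=O)[O-])cc1`, with > 150000 nM in this assay.
Compound 3, `COc1cc(OC)c(OC)cc1/C=C/C(=O)c1cccc(C(F)(F)F)c1`, with > 150000 nM in this assay.

Compound 2 stands at the edge of what this assay can report: its value of > 150000 nM is a limit of the assay, not a number. The same holds for compound 3, whose value of > 150000 nM is likewise a limit. Only compound 1, with 108000 nM, gives a measured number, so the three values together show two compounds sitting at the limit of > 150000 nM in this assay, at which 2 of the 3 values shown sit, and one within reach of the read-out.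

The next compound, compound 4, `COc1cc(OC)c(OC)cc1/C=C/C(=O)c1ccc(Br)cc1`, is not yet measured. It differs from compound 2 in one place: bromo in place of nitro on an aromatic carbon. Among the measured compounds shown here, no step between measured compounds is available to judge how this change plays out, and the two limits leave the comparison among compounds 2 and 3 open.

With compound 2 at a limit, no step beyond the usual scatter is expected, and the step of an at least 1.1-fold lower number from compound 2 to compound 4 (0.06 log units; that floor lies within the scatter) is estimated to be small. Compound 4 is therefore expected to give about 130000 nM, with a range from 40000 nM to 400000 nM, and a fair chance that this assay again reports only a limit.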

Compound 4, half-maximal inhibitory concentration: 31700 nM
Compound 4: the middle estimate sits 4.1-fold (0.61 log units) above what was measured, outside the stated range (below it).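

Placing bromo instead of nitro on this aromatic carbon, para to a large group, gives a step that can be read in this assay: an at least 4.7-fold lower number from compound 2 to compound 4 (0.67 log units; beyond the scatter). Compound 2 has only a limit, so this step is a floor and the real gap may be wider: the limit of > 150000 nM in this assay, at which 2 of the 4 values shown sit. Among the compounds shown here, it shows that the group at this position can move the read-out beyond the scatter, which the earlier compounds, with one number and two limits, could not show.

The compounds shown do not tell whether the lower number belongs to bromo itself or would also appear with another group at this position, such as chloro, methoxy or an amine. With a single readable step at this position, they also give no order among groups there.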